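Aromatic ring in place of saturated ring on the carbonyl

The source may hold more compounds than are shown below. What is called first, only, known or untested is meant among the compounds shown, and "the series" means these compounds.

Compound 1 `O=C(C1CCCCC1)N1CC(c2nc(-c3cccc(F)c3)no2)C1`: in an assay on HEK293 cells for negative allosteric modulation of metabotropic glutamate receptor 5 (Homo sapiens), read by FLIPR (on this read-out higher numbers stand for weaker inhibition and lower numbers for stronger inhibition), compound 1 gives > 10000 nM, a limit of the assay.
Compound 2 `CC1CCC(C(=O)N2CC(c3nc(-c4cccc(Cl)c4)no3)C2)CC1`: in this assay compound 2 gives > 10000 nM, a limit of the assay.
Compound 3 `O=C(C1CCC(C(F)(F)F)CC1)N1CC(c2nc(-c3cccc(Cl)c3)no2)C1`: in this assay compound 3 gives > 10000 nM, a limit of the assay.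

Compound 2 cannot be placed among these numbers: its own value in this assay is a limit, and the two other values shown are limits as well, so no order among compounds 1, 2 and 3 can be read. For the measured compounds named here, the single step between measured compounds, a step that the two limits leave unreadable from compound 2 to compound 3, trifluoromethyl in place of methyl on a saturated ring carbon, cannot be sized because of the limit of > 10000 nM in this assay, at which 3 of the 3 values shown sit.

Compound 4 `O=C(c1ccccc1F)N1CC(c2nc(-c3cccc(Cl)c3)no2)C1` differs from compound 2 by 2-fluorophenyl in place of 4-methylcyclohexyl on a carbonyl carbon. Going by the values given here, no measured step bears on a change of this kind: none of compounds 1, 2 or 3 carries an aromatic ring on that carbonyl carbon, and the one measured step hides its own size. The expectation for compound 4 therefore rests only on the observation that every compound with a saturated ring on the carbonyl carbon sits at the limit, and on the untested possibility that an aromatic ring there changes this. For compound 4 a step of an at least 5.0-fold lower number from compound 2 to compound 4 (0.69 log units; beyond the scatter) toward stronger inhibition is estimated, with wide uncertainty. Compound 4 is estimated at 2000 nM, with a range from 200 nM to 20000 nM.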

Compound 4, half-maximal inhibitory concentration: 670 nM
Compound 4: the middle estimate sits 3.0-fold (0.47 log units) above what was measured; the range from low to high includes it.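

In this assay, the carbonyl carbon proves to be a place where the read-out can move: 2-fluorophenyl in place of 4-methylcyclohexyl gives an at least 14-fold lower number from compound 2 to compound 4 (1.17 log units; beyond the scatter), toward stronger inhibition. The two groups have the same count of heavy atoms, neither carries a hydrogen-bond donor or acceptor, and neither has a net charge, yet the change replaces a non-aromatic ring of carbon only with an aromatic one and also brings in fluorine. The printed step is only a lower bound on the true difference, because compound 2 sits at a limit rather than at a number: the limit of > 10000 nM in this assay, at which 3 of the 4 values shown sit.

For the compounds shown here, the single step cannot separate the aromatic ring from its fluorine, so what a plain phenyl or a pyridine ring would give on that carbonyl carbon remains open. Also open, as far as these compounds go, is whether a large step of this kind would recur with another group on the second aromatic ring of the shared core, such as a methoxy group in place of the chlorine of compound 4.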